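Lengthening the Tetrazole Tether in a Leukotriene Receptor Series

This account rests on a few compounds, and the source may have more. Where it says the series, first, only, none or still open, it means among the compounds named here.

Compound 1 `c1cc(OCc2ccc3ccccc3n2)cc(-c2nn[nH]n2)c1`: 200 nM
Compound 2 `c1ccc2nc(COc3ccc(Cc4nnn[nH]4)cc3)ccc2c1`: 1000 nM
Compound 3 `c1ccc2nc(COc3ccc(CCc4nnn[nH]4)cc3)ccc2c1`: 280 nM

Three compounds share one core and differ only in how the tetrazole is tied to the six-membered aromatic ring of carbon only. In a functional assay (Cavia porcellus) for inhibition of cysteinyl leukotriene receptor (Homo sapiens) (a lower number here means a stronger inhibitor, a higher number a weaker inhibitor), compound 1 gives 200 nM, compound 2 gives 1000 nM and compound 3 gives 280 nM. Compound 3 therefore holds the second highest number of the three: it and compound 1 lie within the scatter of each other, while compound 2 sits beyond the scatter above it. Within the data shown here, the one measured step that speaks to the next change is a 3.6-fold lower number from compound 2 to compound 3 (0.55 log units; beyond the scatter), in which the tether between the ring and the tetrazole became longer.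

Compound 4 `c1ccc2nc(COc3ccc(SCCCc4nnn[nH]4)cc3)ccc2c1` has not yet been measured. From compound 3 to compound 4, (a group of 9 heavy atoms (4 carbon, 4 nitrogen, 1 sulfur; one five-membered aromatic ring with 4 hetero atoms) in place of a group of 7 heavy atoms (3 carbon, 4 nitrogen; one five-membered aromatic ring with 4 hetero atoms), on an aromatic carbon). The tether grows longer once more and now includes a sulfur. Because the earlier lengthening gave a 3.6-fold lower number from compound 2 to compound 3 (0.55 log units; beyond the scatter), a further modest lowering, or no change beyond the scatter, is the expected outcome, so compound 4 is expected to show a 1.9-fold lower number from compound 3 to compound 4 (0.27 log units; within the scatter). Compound 4 is estimated at 150 nM, within a range from 50 nM to 500 nM.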

Compound 4, half-maximal inhibitory concentration: 25 nM
The estimate for compound 4 lay 6.0-fold (0.78 log units) above the measured number; the measured number lies below the stated range.
By their numbers in this assay, from the lowest: compound 4; then compounds 1 and 3 (each within the scatter of the next); then compound 2.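

In this assay, putting the longer sulfur-containing tether in place of 2-(1H-tetrazol-5-yl)ethyl, on an aromatic carbon para to a large group, gives an 11-fold lower number from compound 3 to compound 4 (1.05 log units; beyond the scatter) and so counts as a large step, whereas the earlier lengthening, a 3.6-fold lower number from compound 2 to compound 3 (0.55 log units; beyond the scatter), was only modest. Taken together, the two changes amount to a 40-fold lower number from compound 2 to compound 4 (1.60 log units; beyond the scatter), so among compounds 2, 3 and 4 the number falls as the tether grows, while compound 1 goes against this pattern, with its tetrazole bound directly to the ring and a value of 200 nM in the same assay. Nothing measured here explains why the number drops so far at this position.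

Compound 4 differs from compound 3 in both tether length and the presence of sulfur, so these compounds cannot show which of the two matters for the step. As far as these compounds go, whether an all-carbon chain of the same length, an oxygen in place of the sulfur, or a carboxylic acid in place of the tetrazole would give a similarly low number remains open.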